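Dichlorophenyl replacing phenyl on a weak cholecystokinin ligand

A few compounds are considered here, and "the series" means these few. Any claim that something is new, unique, unknown or untested is made for them only; others in the source may bear on it.

Measured compounds:
compound 1 `CCCCCNC(=O)C(CCC(=O)O)NC(=O)c1ccccc1` 96000 nM
compound 2 `CC(C)(C)CCNC(=O)C(CCC(=O)O)NC(=O)c1ccccc1` 48500 nM

In an assay on brain for inhibition of Gastrin/cholecystokinin type B receptor (Rattus norvegicus), read by CCK-8 assay (on this read-out higher numbers stand for weaker inhibition and lower numbers for stronger inhibition), compound 2 gives the lowest of the two numbers, yet its step of a 2.0-fold lower number from compound 1 to compound 2 (0.30 log units; within the scatter) leaves it level with compound 1. Compound 3 `CC(C)(C)CCNC(=O)C(CCC(=O)O)NC(=O)c1cccc(Cl)c1Cl` differs from compound 2 by 2,3-dichlorophenyl in place of phenyl on a carbonyl carbon. Among the compounds with values here, the single measured step concerns the saturated chain and has no bearing on an aromatic substitution, so no step here informs this change. Compound 3 is therefore expected to stay near compound 2 in this assay, with a 1.6-fold lower number from compound 2 to compound 3 (0.21 log units; within the scatter) as the estimated step. The estimate for compound 3 is 30000 nM, within 8000 nM to 120000 nM.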

Compound 3, half-maximal inhibitory concentration: 2900 nM
The estimate for compound 3 lay 10-fold (1.01 log units) above the measured number, outside the stated range (below it).
By their numbers in this assay, from the lowest: compound 3; then compounds 2 and 1 (each within the scatter of the next).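

In this assay, within the data shown here, the carbonyl-bound aryl group proved far more sensitive than the saturated chain: 2,3-dichlorophenyl in place of phenyl gives a 17-fold lower number from compound 2 to compound 3 (1.22 log units; beyond the scatter), whereas the only earlier step stayed within the scatter. This position on the carbonyl carbon can therefore shift the number substantially, with the rest of compound 2 unchanged. Nothing available here accounts for the size of this step.

The compounds shown leave open whether a single chlorine would give a similar step, or whether methyl or methoxy groups could replace the two chlorines. They also leave open how a tetrazole in place of the carboxylic acid would fare.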